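Swapping a furan for a fluorophenyl at the far end of compound 3

This account rests on a few compounds, and the source may have more. Where it says the series, first, only, none or still open, it means among the compounds named here.

Measured so far:
- compound 1 `CC(C)C[C@@H](N)CN(C(=O)[C@@H]1C[C@H]1c1ccccc1)c1ccc(-c2ccccc2)cc1`: 1.8 nM
- compound 2 `CC(C)C[C@H](N)CCN(C(=O)[C@@H]1C[C@H]1c1ccccc1)c1ccc(-c2ccccc2)cc1`: 3 nM
- compound 3 `CC(C)C[C@H](N)CN(C(=O)[C@@H]1C[C@H]1c1ccccc1)c1ccc(-c2ccoc2)cc1`: 2000 nM

In a functional assay for agonist activity at G protein-coupled receptor 88 (Homo sapiens), read by HTRF and cAMP accumulation (a lower number here means that less compound is needed, a higher number that more compound is needed for the effect), compound 3 gives the highest of the three numbers, well beyond the scatter from both compound 1 and compound 2. Within the data shown here, the only step measured directly, a 1.7-fold higher number from compound 1 to compound 2 (0.22 log units; within the scatter), lies within the scatter and concerns the amine-bearing chain, not the aromatic end. Compound 4 `CC(C)C[C@H](N)CN(C(=O)[C@@H]1C[C@H]1c1ccccc1)c1ccc(-c2ccccc2F)cc1` differs from compound 3 by 2-fluorophenyl in place of furan-3-yl on an aromatic carbon. Among the measured compounds shown here, no measured step covers this exact change. What the values do show is that compound 1 and compound 2, which both carry a plain phenyl at this position, give low numbers in this assay, while compound 3, with the furan-3-yl, gives a far higher one; the chain and its stereochemistry also differ between them, so the comparison is not clean. A 2-fluorophenyl resembles that phenyl more than the furan does, so a large drop is expected from compound 3 to compound 4, a 100-fold lower number from compound 3 to compound 4 (2.00 log units; beyond the scatter), though not all the way to the level of compound 1. Compound 4 is estimated at 20 nM, with a likely range of 4 nM to 150 nM.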

Compound 4, half-maximal effective concentration: 1600 nM
Beside the measured number, compound 4's estimate is 80-fold (1.90 log units) below it; measured number outside the range, above it.
By their numbers in this assay, from the lowest: compounds 1 and 2 (each within the scatter of the next); then compounds 4 and 3 (each within the scatter of the next).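

In this assay, putting 2-fluorophenyl in place of furan-3-yl gives a 1.3-fold lower number from compound 3 to compound 4 (0.10 log units; within the scatter), so at this position the two groups cannot be told apart. The high number of compound 3 is therefore not peculiar to furan-3-yl: compound 4 carries no oxygen and has a six-membered aromatic ring of carbon only, yet its number stands with that of compound 3. Nothing available here explains why these two different rings read alike.

Still open, as far as these compounds go, is how a plain phenyl at this position would read on the exact amine-bearing chain shared by compound 3 and compound 4, which would show whether the ring or the arrangement of that chain matters more. Also open, from the compounds shown here alone, is how a pyridine ring or a methoxy group on the phenyl ring would read here.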